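From methoxy to isopropoxy on the shared core

The source may report more compounds than this note shows. Statements on the series, on what has been measured and on what is new or still open speak of the compounds shown alone.

Going by the values given here, in a functional assay on MCF7 cells (Homo sapiens) for antiproliferative activity, read by sulforhodamine B assay, with a stated time of 72 h (a higher number here means a weaker inhibitor, a lower number a stronger inhibitor), compound 1 (`Cc1ccc(O)c(C(=O)/C=C/c2csc3ccccc23)c1`) gives 7800 nM and compound 2 (`COc1ccc(O)c(C(=O)/C=C/c2csc3ccccc23)c1`) gives 750 nM as the lower of the two numbers measured so far. Among the compounds with values here, the only measured step is a 10-fold lower number from compound 1 to compound 2 (1.02 log units; beyond the scatter) with methoxy in place of methyl on an aromatic carbon, and it is large and beyond the scatter. Compound 3 (`CC(C)Oc1ccc(O)c(C(=O)/C=C/c2csc3ccccc23)c1`) has isopropyl in place of methyl on an oxygen on an aromatic ring, a change of isopropyl in place of methyl on an oxygen on an aromatic ring that reads methoxy to isopropoxy. Within the data shown here, the large step from compound 1 bears on this only in part, since no measured pair shows a change of the group on that oxygen. A small rise in this assay is therefore expected, with an estimated step of a 1.9-fold higher number from compound 2 to compound 3 (0.27 log units; within the scatter) and little confidence in its direction. For compound 3 the estimate is 1400 nM with an expected range from 450 nM to 4500 nM in this reading.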

Compound 3, half-maximal inhibitory concentration: 6600 nM
Compound 3: middle estimate off by 4.7-fold (0.67 log units), on the low side, outside the stated range (above it).
By their numbers in this assay, from the lowest: compound 2; then compounds 3 and 1 (each within the scatter of the next).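

In this assay, going by these compounds alone, the first measured change of the group on this oxygen gives an 8.8-fold higher number from compound 2 to compound 3 (0.94 log units; beyond the scatter), so the low number of compound 2 does not carry over from methoxy to isopropoxy. Isopropoxy in place of methyl on the aromatic carbon gives a 1.2-fold lower number from compound 1 to compound 3 (0.07 log units; within the scatter), which leaves compound 3 and compound 1 level within the scatter, and of the three groups at this place only the methoxy of compound 2 stands apart. No measurement offered here explains why these two ethers differ so much.

The compounds shown leave open whether an ethoxy group, with its intermediate chain on the same oxygen, would read like methoxy or like isopropoxy. They also leave open how a free hydroxyl or an amine would read at this place on the shared core.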